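A few compounds are considered here, and "the series" means these few. Any claim that something is new, unique, unknown or untested is made for them only; others in the source may bear on it.

Measured so far:
- compound 1, `Cc1ccc(-c2csc(=N)n2CC(=O)N2CCN(c3ccccc3)CC2)cc1`: 4290 nM
- compound 2, `N=c1scc(-c2ccccc2)n1CC(=O)N1CCN(c2ccccc2)CC1`: 643 nM

Both numbers come from an assay on isolated protein for inhibition of leukotriene A-4 hydrolase (Homo sapiens); on this read-out lower numbers stand for stronger inhibition and higher numbers for weaker inhibition. Compound 2 gives the lowest of the two numbers in this assay; its nearest neighbour is compound 1, with a number higher by a 6.7-fold lower number from compound 1 to compound 2 (0.82 log units; beyond the scatter) read in reverse, a difference beyond the usual scatter.

Compound 3, `N=c1scc(-c2ccc(Cl)cc2)n1CC(=O)N1CCN(c2ccccc2)CC1`, has not yet been measured. It differs from compound 2 by chloro in place of hydrogen on an aromatic carbon, on an aromatic carbon of a six-membered aromatic ring of carbon only, para to a large group, so that phenyl becomes 4-chlorophenyl.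

For the measured compounds named here, only one measured step speaks to this change: the step from compound 1 to compound 2, in which a methyl at that same place was replaced by hydrogen, improved the number by a 6.7-fold lower number from compound 1 to compound 2 (0.82 log units; beyond the scatter). Putting a group back at that place, now chloro rather than methyl, is therefore expected to move the number in the opposite direction, though a chloro is not a methyl and the size is uncertain. A modest worsening is expected, a 2.2-fold higher number from compound 2 to compound 3 (0.34 log units; beyond the scatter), giving compound 3 an estimated value of 1400 nM, within a range from 500 nM to 4500 nM.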

Compound 3, inhibition constant: 93 nM
Beside the measured number, compound 3's estimate is 15-fold (1.18 log units) above it; the measured number lies below the stated range.
By their numbers in this assay, from the lowest: compound 3; then compound 2; then compound 1.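

In this assay, this place on the aromatic ring does not simply reject any group larger than hydrogen: chloro in place of hydrogen gives a 6.9-fold lower number from compound 2 to compound 3 (0.84 log units; beyond the scatter), the opposite direction from the earlier methyl, whose removal gave a 6.7-fold lower number from compound 1 to compound 2 (0.82 log units; beyond the scatter). Comparing the two groups directly, chloro in place of methyl gives a 46-fold lower number from compound 1 to compound 3 (1.66 log units; beyond the scatter), so among these three compounds the result depends on which group sits at this place, and not only on whether the place is filled. Nothing measured here explains why chloro and methyl part so widely.

The compounds shown carry only hydrogen, methyl or chloro at this place, so it remains open how fluoro, bromo, methoxy or trifluoromethyl would read there, and whether the trend with chloro extends to any of these other groups. Going by these compounds, it is also open whether chloro would give a similar step if it stood elsewhere on the same ring, or if another part of the shared core were changed at the same time.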